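Methylsulfonyl for methoxy on the aryl of compound 1

A few compounds are considered here, and "the series" means these few. Any claim that something is new, unique, unknown or untested is made for them only; others in the source may bear on it.

Within the data shown here, compound 1 `COc1ccc(-n2c(C)nc3c(NC(C4CC4)C4CC4)nc(C)nc32)cc1` carries a methoxy on its pendant aromatic ring and is the stronger of the two compounds measured so far: in a functional assay on CHO cells for antagonist activity at corticotropin-releasing factor receptor 1 (Homo sapiens), read by cAMP accumulation (a lower number here means a stronger inhibitor, a higher number a weaker inhibitor), compound 1 gives 19 nM. Compound 2 `COc1ccc(-n2c(C3CC(F)(F)C3)nc3c(NC(C4CC4)C4CC4)nc(C)nc32)cc1`, which differs only at the aromatic carbon of the core where a 3,3-difluorocyclobutyl replaces methyl, gives 261 nM in this assay, a change of a 14-fold higher number from compound 1 to compound 2 (1.14 log units; beyond the scatter). Compound 3 `Cc1nc(NC(C2CC2)C2CC2)c2nc(C)n(-c3ccc(S(C)(=O)=O)cc3)c2n1` is not yet measured; it differs from compound 1 by methylsulfonyl in place of methoxy on an aromatic carbon. Among the measured compounds shown here, the only measured step, from compound 1 to compound 2, concerns a different place on the core and so bears only indirectly on this exchange. Without a closer comparison, the expectation for compound 3 is a modest weakening, a 3.2-fold higher number from compound 1 to compound 3 (0.50 log units; beyond the scatter), in this assay. Compound 3 is therefore estimated at 60 nM, expected to fall between 15 nM and 250 nM.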

Compound 3, inhibition constant: 140 nM
Compound 3: middle estimate off by 2.3-fold (0.37 log units), on the low side, and the stated range covers the measured number.
By their numbers in this assay, from the lowest: compound 1; then compounds 3 and 2 (each within the scatter of the next).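

Among these compounds, the exchange of methoxy for methylsulfonyl on the pendant aromatic ring, at the carbon para to a large group, gives the first reading at this position: in this assay it brings a 7.4-fold higher number from compound 1 to compound 3 (0.87 log units; beyond the scatter). The position is therefore not indifferent to its substituent, and together with a 14-fold higher number from compound 1 to compound 2 (1.14 log units; beyond the scatter), this makes a second place on compound 1 where the single change shown raises the number, with neither step going against that. No measurement shown here accounts for the size of the step at this position.

A single replacement cannot show whether the methoxy itself is favoured or the methylsulfonyl specifically disfavoured. Going by these compounds, whether a chlorine, an ethoxy, a dimethylamino group or a sulfonamide at the same carbon would stay nearer to compound 1 remains open.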